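Azetidinyl in Place of Hydrogen on a Low-Toxicity Core

The compounds below may be only part of what the source reports. "The series", "measured", "known", "first", "only" and "open" are said of these compounds alone.

Measured so far:
Compound 1 `CC(C)(C)n1c(=O)n(Cc2cc3cc(Cl)ccc3n2CCCS(C)(=O)=O)c2cnccc21`: in an ADME assay on HeLa cells (Homo sapiens) for cytotoxicity, read by ATP content, with a stated time of 3 days (on this read-out higher numbers stand for lower toxicity in this test and lower numbers for higher toxicity in this test), compound 1 gives > 50000 nM, which is a limit of the assay rather than a number.
Compound 2 `CS(=O)(=O)CCCn1c(Cn2c(=O)[nH]c3ccncc32)cc2cc(Cl)ccc21`: in this assay compound 2 gives > 50000 nM, again a limit of the assay.

Compound 2 therefore stands at the limit, as do both values shown so far (the limit of > 50000 nM in this assay, at which 2 of the 2 values shown sit). Going by the values given here, the one measured step, a step that the two limits leave unreadable from compound 1 to compound 2, cannot be read in size because both ends are limits. Compound 3 `CS(=O)(=O)CCCn1c(Cn2c(=O)n(C3CNC3)c3ccncc32)cc2cc(Cl)ccc21` differs from compound 2 by azetidin-3-yl in place of hydrogen on an aromatic nitrogen. Among the compounds with values here, nothing measured tells how such a group shifts this read-out; the only guidance is that the shared core has twice stayed at the limit (the limit of > 50000 nM in this assay, at which 2 of the 2 values shown sit). The expectation for this assay is therefore no step beyond the scatter, with a step of a number no higher from compound 2 to compound 3 (the limit leaves the size open) estimated from compound 2 to compound 3. Compound 3 is estimated at 50000 nM, with a range from 20000 nM to 120000 nM.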

Compound 3, half-maximal cytotoxic concentration: > 50000 nM
Compound 3 gave a limit, no number; the forecaster's own chance of this, stated with the estimate: 70%; the middle value sits exactly at the limit.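

Going by these compounds alone, compound 1, compound 2 and compound 3 each give a limit rather than a number in this assay and no step among them can be read. Still open is whether tert-butyl, hydrogen or azetidin-3-yl on that aromatic nitrogen makes any difference to this read-out: the limit of > 50000 nM in this assay, at which 3 of the 3 values shown sit.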